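The source may hold more compounds than are shown below. What is called first, only, known or untested is meant among the compounds shown, and "the series" means these compounds.

Measured so far in a functional assay on KG-1 cells (Homo sapiens) for cytotoxicity, read by luminescence and CellTiter-Glo, with a stated time of 3 days; on this read-out lower numbers stand for stronger inhibition and higher numbers for weaker inhibition:
- Compound 1 `O=C(Nc1cc(C(F)(F)F)cc(C(F)(F)F)c1)c1cc(Cl)c(F)cc1O`: 470 nM
- Compound 2 `COc1ccc(O)c(C(=O)Nc2ccc(C#N)cc2)c1`: > 10000 nM
- Compound 3 `O=C(Nc1cc(F)cc(F)c1)c1ccc2cccnc2c1O`: 3340 nM

Compound 2 gives > 10000 nM, which is a limit of the assay and not a number. The wider picture is the limit of > 10000 nM in this assay, at which 1 of the 3 values shown sits. Its true position is therefore open on one side, and any comparison with it can only be made against that limit.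

The next compound to read is compound 4 `N#Cc1ccc(NC(=O)c2cc(-c3ccccc3)ccc2O)cc1`. It keeps the rest of compound 2 and carries phenyl in place of methoxy on an aromatic carbon, para to a hydroxy group: phenyl in place of methoxy on an aromatic carbon.

Among the compounds with values here, no measured pair in this small set differs in one place, so the expected size of the step in this assay rests on weak ground. A modest move towards stronger inhibition is expected, with a real chance that compound 4 also stays at the limit. The reference for a measurable value in this set is compound 3 at 3340 nM, and a result as strong as compound 1 at 470 nM is not expected.

The estimated change is an at least 2.0-fold lower number from compound 2 to compound 4 (0.30 log units; that floor lies within the scatter). For compound 4 the expected value is 5000 nM, with an estimated range of 1200 nM to 20000 nM.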

Compound 4, half-maximal inhibitory concentration: 1300 nM
Compound 4: middle estimate off by 3.8-fold (0.59 log units), on the high side; measured number inside the range.
By their numbers in this assay, from the lowest: compound 1; then compound 4; then compound 3. At a limit, above all of these: compound 2.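

In this assay, the position para to a hydroxy group now has its first readable step: phenyl in place of methoxy gives an at least 7.6-fold lower number from compound 2 to compound 4 (0.88 log units; beyond the scatter). Compound 2 gives > 10000 nM, which is a limit of the assay and not a number, so the true size of the step is open on one side: the limit of > 10000 nM in this assay, at which 1 of the 4 values shown sits. The change brings in one six-membered aromatic ring of carbon only and removes one hydrogen-bond acceptor, and this single pair cannot separate the arrival of phenyl from the departure of methoxy.

As far as these compounds go, what an amine or a carboxylic acid at this same position would give remains open, as does whether a saturated ring such as cyclohexyl would match phenyl there. From the compounds shown here alone, whether the same change carries over to the cores of compound 1 or compound 3 is also open, with one pair in one assay as the only support so far.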